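Adding a Second Methoxy Group to Compound 3

This account rests on a few compounds, and the source may have more. Where it says the series, first, only, none or still open, it means among the compounds named here.

Compound 1, `COc1ccc(-c2cc(NC(=S)NNC(=O)c3ccc(C)cc3)cs2)cc1`, gives 30000 nM in a functional assay on Hs 683 cells (Homo sapiens) for inhibition, read by colorimetric assay and MTT assay, with a stated time of 72 h; a lower number here means a stronger inhibitor, a higher number a weaker inhibitor.
Compound 2, `Cc1ccc(C(=O)NNC(=S)Nc2csc(-c3ccccc3)c2)cc1`, gives 37000 nM in this assay.
Compound 3, `COc1ccc(C(=O)NNC(=S)Nc2csc(-c3ccccc3)c2)cc1`, gives 35000 nM in this assay.

All three measured values lie within the scatter of one another. The change methoxy in place of hydrogen on an aromatic carbon gave a 1.2-fold lower number from compound 2 to compound 1 (0.09 log units; within the scatter). The cores of compound 2 and compound 3 differ by methoxy in place of methyl on an aromatic carbon, also within the scatter. Compound 4, `COc1ccc(C(=O)NNC(=S)Nc2csc(-c3ccccc3)c2)cc1OC`, differs from compound 3 by methoxy in place of hydrogen on an aromatic carbon. This is the same kind of change as that from compound 2 to compound 1, not the same: there the entering group sat para to a large group, here it sits ortho to a methoxy group and meta to a large group. Because the earlier step of a 1.2-fold lower number from compound 2 to compound 1 (0.09 log units; within the scatter) stayed within the scatter, a similarly small step is expected here, a 1.1-fold lower number from compound 3 to compound 4 (0.03 log units; within the scatter). Compound 4 is estimated at 33000 nM, between 15000 nM and 75000 nM.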

Compound 4, half-maximal inhibitory concentration: 22000 nM
Compound 4: middle estimate off by 1.5-fold (0.18 log units), on the high side; the measured number falls inside the stated range.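

The entry of methoxy in place of hydrogen on an aromatic carbon gave a 1.6-fold lower number from compound 3 to compound 4 (0.20 log units; within the scatter) in this assay. Set beside the earlier step, the same change on the two cores shows no difference that can be told apart: the same change on two cores in this assay, a 1.2-fold lower number (0.09 log units; within the scatter) from compound 2 to compound 1 and a 1.6-fold lower number (0.20 log units; within the scatter) from compound 3 to compound 4, 1.3-fold (0.11 log units) apart, within the scatter of two such steps

This shows that the change behaved alike on these two cores, but with both steps inside the scatter, it does not show that methoxy lowers the number on either core, nor how the change would behave on any further core.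

Still open, going by these compounds, is whether a different group on the same aromatic carbon, such as an amine, a carboxylic acid or a longer chain, would give a step beyond the scatter.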